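The source may report more compounds than this note shows. Statements on the series, on what has been measured and on what is new or still open speak of the compounds shown alone.

The measured compounds:
compound 1, `CCN(CC)c1cc2[nH]c(C3CCCCC3)nc2cc1NC(=O)c1ccc(N(C)C)cc1`: in an ADME assay on Vero cells (Chlorocebus sabaeus) for cytotoxicity, read by resazurin assay, with a stated time of 3 days (on this read-out lower numbers stand for stronger inhibition and higher numbers for weaker inhibition), compound 1 gives "not determined" (no result reported).
compound 2, `CCCCOC(=O)Nc1cc2nc(C3CCCCC3)[nH]c2cc1N(CC)CCN(C)C`: in this assay compound 2 gives > 100 ug/mL, a limit of the assay rather than a number.
compound 3, `CCCCOC(=O)Nc1cc2nc(C3CCCCC3)[nH]c2cc1N(C)CCN(C)C`: in this assay compound 3 gives > 100 ug/mL, again a limit of the assay rather than a number.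

Compound 1 stands nowhere on the numbers shown: no result was reported for it in this assay, and the two other values are limits. Among the measured compounds shown here, the one step between measured compounds is a step that the two limits leave unreadable from compound 2 to compound 3; both of its ends are limits, so it yields no size. What the two measured compounds share is the limit of > 100 ug/mL in this assay, at which 2 of the 3 values shown sit.

Compound 4, `CCN(CC)c1cc2[nH]c(C3CCCCC3)nc2cc1NC(=O)c1ccc(Br)cc1`, differs from compound 1 in one place: bromo in place of dimethylamino on an aromatic carbon. For the measured compounds named here, no measured step bears on this change: compound 1 has no number, and the one measured step concerns a different change on another part of the shared core. Going by the values given here, no direction or size can be drawn from the data; the only guide is that both compounds that were measured reached (the limit of > 100 ug/mL in this assay, at which 2 of the 3 values shown sit). Compound 4 is therefore expected to sit near 100 ug/mL, within a range from 30 ug/mL to 300 ug/mL, with a fair chance that only a limit is reported.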

Compound 4, half-maximal inhibitory concentration: > 100 ug/mL
Compound 4 was reported as a limit; the forecaster's own chance of this, stated with the estimate: 65%; the middle value sits exactly at the limit.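

No new step can be read: compound 1 has no reported result in this assay, so the change from 4-(dimethylamino)phenyl to 4-bromophenyl that leads to compound 4 has no size. Compound 4 gives > 100 ug/mL, a limit of the assay and not a number. The compounds shown leave open how strongly compound 2, compound 3 and compound 4 affect the cells, and whether any of these changes alters that.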